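Solubility limit from compound 3 to compound 4

A few compounds are considered here, and "the series" means these few. Any claim that something is new, unique, unknown or untested is made for them only; others in the source may bear on it.

In a physicochemical assay for solubility (on this read-out higher numbers stand for higher solubility and lower numbers for lower solubility), compound 1 `O=C(O)c1ccc(C(=O)/C(=C\c2ccc(F)c([N+](=O)[O-])c2)SCc2ccc(Cl)cc2Cl)cc1` gives < 1000 ug/mL as a limit and not a number. Compound 2 `O=C(O)c1ccc(C(=O)/C(=C\c2ccc(Cl)c([N+](=O)[O-])c2)SCc2ccc(Cl)cc2)cc1` likewise gives < 1000 ug/mL as a limit. Compound 3 `O=C(O)c1ccc(C(=O)/C(=C\c2ccc(O)c([N+](=O)[O-])c2)SCc2ccc(Br)cc2)cc1` gives < 1000 ug/mL as a limit too. Compound 3 therefore has no number of its own and stands with the other two at the limit of < 1000 ug/mL in this assay, at which 3 of the 3 values shown sit, for now. For the measured compounds named here, compound 4 `O=C(O)c1ccc(C(=O)/C(=C\c2ccc([N+](=O)[O-])cc2F)SCc2ccc(Br)cc2)cc1` carries 2-fluoro-4-nitrophenyl in place of 4-hydroxy-3-nitrophenyl on a double-bonded chain carbon bound to a double-bonded chain carbon as its one change. Going by the values given here, no pair of measured compounds gives a step size, so no shift beyond the scatter is expected in this assay in either direction. The estimated change is a step that the limit leaves unreadable from compound 3 to compound 4 on that basis. Compound 4 is expected at 700 ug/mL with an estimated range of 250 ug/mL to 1000 ug/mL and a further limit reading is likely.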

Compound 4, solubility: < 1000 ug/mL
Compound 4: only a limit was reported; the forecaster's own chance of this, stated with the estimate: 85%; the middle value lies beyond the limit too.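

In this assay no step can be read from compound 3 to compound 4, as both readings are limits and not numbers: the limit of < 1000 ug/mL in this assay, at which 4 of the 4 values shown sit.

The compounds shown leave open the size and direction of any effect of 2-fluoro-4-nitrophenyl in place of 4-hydroxy-3-nitrophenyl in this assay.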